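A few compounds are considered here, and "the series" means these few. Any claim that something is new, unique, unknown or untested is made for them only; others in the source may bear on it.

Three compounds have been measured so far:
compound 1, `CC(C)Cc1ccc2c(NCCCNCc3ccco3)ccnc2c1`, 16000 nM
compound 2, `COc1cccc(CNCCCNc2ccnc3cc(Oc4ccc(Cl)cc4)ccc23)c1O`, 5700 nM
compound 3, `COc1ccc(F)cc1CNCCCNc1ccnc2cc(CC(C)C)ccc12`, 2900 nM

These numbers come from an ADME assay on HepG2 cells (Homo sapiens) for cytotoxicity, read by luminescence, CellTiter-Glo and ATP content, with a stated time of 72 h; on this read-out lower numbers stand for an effect already at smaller amounts and higher numbers for an effect only at larger amounts of compound. Compound 1 stands at the highest number of the three: compound 2 gives 5700 nM and compound 3 gives 2900 nM, both beyond the scatter from compound 1, so compound 1 shows the effect only at the largest amount.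

Compound 4, `COc1ccc(Oc2ccc3c(NCCCNCc4ccco4)ccnc3c2)cc1`, has not yet been measured. It differs from compound 1 in one place: 4-methoxyphenoxy in place of isobutyl on an aromatic carbon.

Within the data shown here, the only step between measured compounds that differ in one place is a 5.5-fold lower number from compound 1 to compound 3 (0.74 log units; beyond the scatter), and that step alters the group on the amine side chain, not the aromatic carbon changed here. Compound 2 and compound 3 each differ from compound 1 in two places, so their values show only that both lie at lower numbers than compound 1. Among the measured compounds shown here, no measured step speaks directly to the present change, and the expectation is therefore loose. The expected step is a 1.6-fold lower number from compound 1 to compound 4 (0.20 log units; within the scatter), a shift toward a lower number that may well stay near the scatter. The estimate for compound 4 is 10000 nM, with a range from 4000 nM to 25000 nM.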

Compound 4, half-maximal effective concentration: 5300 nM
Beside the measured number, compound 4's estimate is 1.9-fold (0.28 log units) above it, and the stated range covers the measured number.
By their numbers in this assay, from the lowest: compounds 3, 4 and 2 (each within the scatter of the next); then compound 1.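

In this assay, putting 4-methoxyphenoxy in place of isobutyl on this aromatic carbon gives a 3.0-fold lower number from compound 1 to compound 4 (0.48 log units; beyond the scatter) and so shows that this position, untouched by any earlier one-place step, also affects the number. Together with a 5.5-fold lower number from compound 1 to compound 3 (0.74 log units; beyond the scatter) on the amine side chain, this means that compound 1 has now moved to a lower number through changes at two separate places. Nothing measured here bears on what lies behind the shift at this carbon.

Going by these compounds, it remains open which part of the entering group matters: its aromatic ring, its linking oxygen or its methoxy group, and a benzyl or a dimethylamino group on this carbon would help to separate these. On these data alone, it is also open whether 4-methoxyphenoxy and the 5-fluoro-2-methoxyphenyl side chain would add up in one compound.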